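Working notes: methoxy added to compound 3

The source may hold more compounds than are shown below. What is called first, only, known or untested is meant among the compounds shown, and "the series" means these compounds.

Measured so far in a functional assay on L1210 cells (Mus musculus) for antiproliferative activity, read by MTT assay, with a stated time of 72 h (on this read-out lower numbers stand for stronger inhibition and higher numbers for weaker inhibition), for the series
compound 1 `COc1ccc(OC)c(C2OC(c3cc(OC)c(OC)c(OC)c3)=NN2C(C)=O)c1` gives 55000 nM
compound 2 `COc1cc(C2=NN(C(C)=O)C(c3ccccc3)O2)cc(OC)c1OC` gives 6400 nM
compound 3 `COc1ccc(C2=NN(C(C)=O)C(c3cccc([N+](=O)[O-])c3)O2)cc1` gives 47000 nM

On these numbers compound 3 lies within the scatter of compound 1, and compound 2 has the lowest number of the three by a margin beyond the scatter.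

Compound 4 `COc1ccc(C2=NN(C(C)=O)C(c3ccc(OC)c([N+](=O)[O-])c3)O2)cc1` is not yet measured. The change from compound 3 is methoxy in place of hydrogen on an aromatic carbon and the new methoxy stands ortho to a nitro group and para to a large group.

For the measured compounds named here, only one measured step bears on this, and only loosely: an 8.6-fold lower number from compound 1 to compound 2 (0.93 log units; beyond the scatter) for phenyl in place of 2,5-dimethoxyphenyl on a saturated ring carbon. Going by the values given here, that step removes methoxy groups and the number falls, but the other aromatic ring there differs from the one in compound 3, and no measured pair adds a methoxy ortho to a nitro group. No step beyond the scatter is therefore expected in this assay and neither direction is favoured with any confidence. The expected step is a 1.3-fold lower number from compound 3 to compound 4 (0.13 log units; within the scatter) with wide uncertainty. Compound 4 is estimated at 35000 nM with an expected range from 11000 nM to 100000 nM on present data.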

Compound 4, half-maximal inhibitory concentration: > 100000 nM
Compound 4 was reported as a limit (the forecaster's own chance of this, stated with the estimate: 10%); at least 2.8-fold (0.45 log units) between middle value and limit.
By their numbers in this assay, from the lowest: compound 2; then compounds 3 and 1 (each within the scatter of the next). At a limit, above all of these: compound 4.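

In this assay compound 4 is reported only as a limit, > 100000 nM, and not as a number: the limit of > 100000 nM in this assay, at which 1 of the 4 values shown sits. Even so, the direction can be read, and methoxy in place of hydrogen on an aromatic carbon, ortho to a nitro group and para to a large group, gives an at least 2.1-fold higher number from compound 3 to compound 4 (0.32 log units; beyond the scatter), so this position does not take the added methoxy without a loss on this read-out, which no earlier pair could show. From the compounds shown here alone, the direction agrees with an 8.6-fold lower number from compound 1 to compound 2 (0.93 log units; beyond the scatter), where methoxy groups leave, but that change is a different one on a different substituent, so the two steps show no general rule for methoxy, and the full size of the new step remains unknown.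

Open, going by these compounds, is whether a smaller or different group on the same aromatic carbon, such as fluorine, a hydroxyl or an amine, would move the number in the same direction. Also open, on these data alone, is whether the step depends on the nitro group, which an amine in its place with the methoxy kept would address, and whether it holds with the other aromatic ring of compound 2.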